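A few compounds are considered here, and "the series" means these few. Any claim that something is new, unique, unknown or untested is made for them only; others in the source may bear on it.

The series rests on the core of compound 1 `CC1=CC[C@@H]([C@@](C)(O)CCCC(C)(C)NC=S)CC1`, which in a functional assay on MCF7 cells (Homo sapiens) for cytotoxicity, read by sulforhodamine B assay (a lower number here means a stronger inhibitor of growth, a higher number a weaker inhibitor of growth), gives 63100 nM. Compound 2 `CC1=CC[C@@H]([C@@](C)(O)CCCC(C)(C)NC(=S)NN)CC1` carries an aminoamino group in place of the hydrogen on the thiocarbonyl carbon; in this assay compound 2 gives 84200 nM. The step of a 1.3-fold higher number from compound 1 to compound 2 (0.13 log units; within the scatter) leaves the read-out essentially where it was. For the measured compounds named here, of the two numbers so far, compound 2 holds the higher one, with compound 1 its only neighbour at a gap within the scatter, so nothing separates the two.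

Compound 3 `CC1=CC[C@@H]([C@@](C)(O)CCCC(C)(C)NC(=S)N/N=C\c2ccccc2)CC1` is not yet measured. It differs from compound 2 in a group of 8 heavy atoms (7 carbon, 1 nitrogen; one six-membered aromatic ring of carbon only) in place of one nitrogen atom, on an amide-type nitrogen. Going by the values given here, the only measured step, that from compound 1 to compound 2, concerns the thiocarbonyl carbon and was within the scatter; no measured step touches the amide-type nitrogen, so nothing bears directly on this replacement. Among the compounds with values here, with no comparable precedent, the expected change is modest, and the estimated step of a 2.1-fold lower number from compound 2 to compound 3 (0.32 log units; beyond the scatter) is set towards a somewhat lower number. For compound 3 the estimate in this assay is 40000 nM, with a range from 15000 nM to 120000 nM.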

Compound 3, concentration for total growth inhibition: 28700 nM
Compound 3: the middle estimate sits 1.4-fold (0.14 log units) above what was measured; low and high end bracket the measured number.
By their numbers in this assay, from the lowest: compound 3; then compounds 1 and 2 (each within the scatter of the next).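

For the compounds shown here, on the amide-type nitrogen whose other neighbour is the thiocarbonyl carbon, the read-out in this assay responds to substitution: the group carrying a six-membered aromatic ring of carbon only, in place of the amino group, gives a 2.9-fold lower number from compound 2 to compound 3 (0.47 log units; beyond the scatter), the first step beyond the scatter. The comparison with the unsubstituted thiocarbonyl carbon points the same way, with a 2.2-fold lower number from compound 1 to compound 3 (0.34 log units; beyond the scatter), so compound 3 holds the lowest number of the three against both neighbours, although both steps remain modest. No measured evidence here accounts for this shift in growth inhibition.

Compound 2 and compound 3 differ by both the aromatic ring and the double bond outside aromatic rings, so the shown data cannot assign the step to either feature. Also open, going by these compounds, is how the same position would read with a pyridine ring, a chlorophenyl group or a saturated cyclohexyl group in place of the phenyl ring, and whether any such group would move the number further than this modest step.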